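The source may hold more compounds than are shown below. What is called first, only, known or untested is meant among the compounds shown, and "the series" means these compounds.

Measured so far:
Compound 1, `Nc1scc(CN2CCN(c3cccc(C(F)(F)F)c3)CC2)c1C(=O)c1ccc(Cl)cc1`: 0%
Compound 2, `Nc1scc(CN2CCN(C3CCCC3)CC2)c1C(=O)c1ccc(Cl)cc1`: 3%
Compound 3, `Nc1scc(CN2CCN(c3cccc4ccccc34)CC2)c1C(=O)c1ccc(Cl)cc1`: 0%

The three share one core and differ only in the group on an amine nitrogen in a ring. In an assay on CHO cells for displacement of a labelled ligand from adenosine receptor A3 (Homo sapiens), read by scintillation counting, with a stated time of 120 min, tested at 10 uM (on this read-out lower numbers stand for less inhibition and higher numbers for more inhibition at the one concentration tested (going by the name of the read-out)), compound 3 gives 0%, level with compound 1 and together with it the lowest of the three numbers; its nearest neighbour is compound 1 with no change at the digits printed from compound 1 to compound 3 (within the scatter), its furthest compound 2 with a number 3 percentage points lower from compound 2 to compound 3 (within the scatter), both within the scatter. Compound 4, `Nc1scc(CN2CCN(c3c(F)cccc3F)CC2)c1C(=O)c1ccc(Cl)cc1`, is not yet measured and differs from compound 3 in one place: 2,6-difluorophenyl in place of naphthalen-1-yl on an amine nitrogen in a ring. Going by the values given here, two measured steps bear on this, since each also swaps the group on that ring nitrogen: no change at the digits printed from compound 1 to compound 3 (within the scatter) and a number 3 percentage points lower from compound 2 to compound 3 (within the scatter). Neither rose above the scatter, whether the nitrogen carried cyclopentyl, 3-(trifluoromethyl)phenyl or naphthalen-1-yl. No step beyond the scatter is therefore expected in this assay, that is a number 2 percentage points higher from compound 3 to compound 4 (within the scatter). Compound 4 is estimated at 2%, within 0% to 12%.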

Compound 4, a percentage reported as inhibition, at one concentration (the size of the read-out at that concentration, not a potency): 4%
Beside the measured number, compound 4's estimate is 2 percentage points below it; the range from low to high includes it.
By their numbers in this assay, from the lowest: compounds 1, 3, 2 and 4 (each within the scatter of the next).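

In this assay, the group on the amine nitrogen in a ring now changes in a new way, with one six-membered aromatic ring bearing two fluorines in place of two fused-in-name naphthalen-1-yl rings, and the read-out does not move beyond the scatter: a number 4 percentage points higher from compound 3 to compound 4 (within the scatter), a number 1 percentage points higher from compound 2 to compound 4 (within the scatter) and a number 4 percentage points higher from compound 1 to compound 4 (within the scatter). Across these four compounds, then, 2,6-difluorophenyl joins cyclopentyl, 3-(trifluoromethyl)phenyl and naphthalen-1-yl as a group that gives no step beyond the scatter at this position. Nothing available explains why the four numbers stay so close together.

Still open, from the compounds shown here alone, is whether a group of another kind on that nitrogen, such as a carboxylic acid or a longer chain ending in an amine, would give a step beyond the scatter. Also open, going by these compounds, is whether a change elsewhere on the shared core would do so.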